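The compounds below may be only part of what the source reports. "The series", "measured", "known", "first", "only" and "open" are said of these compounds alone.

Measured so far in a functional assay on NIH3T3 cells (Mus musculus); a higher number here means that more compound is needed for the effect, a lower number that less compound is needed:
Compound 1 `CSCNC(=O)c1ccc(NCc2cncn2Cc2ccc(C#N)cc2)cc1-c1ccccc1` gives > 10 uM, a limit of the assay rather than a number.
Compound 2 `COC(=O)[C@H](CCSC)NC(=O)c1ccc(CN(Cc2c[nH]cn2)Cc2c[nH]cn2)cc1-c1ccccc1C` gives > 10 uM, again only a limit.
Compound 3 `CSCC[C@H](NC(=O)c1ccc(NCc2cncn2Cc2ccc(Cl)cc2)cc1-c1ccccc1)C(=O)O` gives > 10 uM, also a limit.

Compound 2 therefore stands at the edge of what this assay can report: its value is a limit, and the other two measured compounds sit at the same limit, as summarised by the limit of > 10 uM in this assay, at which 3 of the 3 values shown sit. Among the compounds with values here, no pair of measured compounds differs in just one place, so no measured step is available to gauge how much a single change moves the read-out here.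

Compound 4 `COC(=O)[C@H](CCSC)NC(=O)c1ccc(CNCc2c[nH]cn2)cc1-c1ccccc1C` is the next compound to be measured in this assay. It differs from compound 2 in one spot: hydrogen in place of (1H-imidazol-4-yl)methyl on an amine nitrogen.

With all three measured values resting at the limit, no step beyond the usual scatter is expected in this assay from this change; the step from compound 2 to compound 4 is estimated as a step that the limit leaves unreadable from compound 2 to compound 4. Compound 4 is expected to give about 15 uM, within a range of 5 uM to 50 uM, most likely reported again only as a limit.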

Compound 4, concentration for half-maximal effect: 25 uM
Compound 4: middle estimate off by 1.7-fold (0.22 log units), on the low side; the measured number falls inside the stated range.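

Compound 2 gives > 10 uM, which is a limit of the assay and not a number. The step from it to compound 4 cannot be read. The compounds shown leave open how far hydrogen in place of (1H-imidazol-4-yl)methyl on the amine nitrogen moves the read-out.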